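Solubility notes: from compound 2 to compound 4

This account rests on a few compounds, and the source may have more. Where it says the series, first, only, none or still open, it means among the compounds named here.

Measured so far:
compound 1 `COc1cccc(Oc2ccc3c(NCCCNCc4cccc(OC)c4O)ccnc3c2)c1` — 14500 nM
compound 2 `COc1cccc(CNCCCNc2ccnc3cc(-c4ccccc4)ccc23)c1O` — 32000 nM
compound 3 `COc1ccc(F)cc1CNCCCNc1ccnc2cc(-c3ccccc3)ccc12` — 32000 nM

In a physicochemical assay for solubility, with a stated time of 18 h, at pH 7.4 (a lower number here means a less soluble compound, a higher number a more soluble compound), compound 2 stands level with compound 3, the two together above compound 1. For the measured compounds named here, the one step at an aromatic carbon of the core, a 2.2-fold higher number from compound 1 to compound 2 (0.34 log units; beyond the scatter), is modest; the step at the chain end, no change at the digits printed from compound 2 to compound 3 (within the scatter), is flat. Compound 4 `COc1cccc(CNCCCNc2ccnc3cc(Cc4cc(C)cc(C)c4)ccc23)c1O` differs from compound 2 in 3,5-dimethylbenzyl in place of phenyl on an aromatic carbon. Going by the values given here, only the step from compound 1 to compound 2 touches the same site, and it was small; nothing here tests a larger group entering there. A step of at most similar size, probably downward or none beyond the scatter, is expected: a 1.6-fold lower number from compound 2 to compound 4 (0.20 log units; within the scatter). Compound 4 is thus estimated at 20000 nM, between 8000 nM and 50000 nM.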

Compound 4, solubility: 4200 nM
For compound 4 the middle estimate is 4.8-fold (0.68 log units) above the measured one; measured number below the stated range.
By their numbers in this assay, from the lowest: compound 4; then compound 1; then compounds 2 and 3 (each within the scatter of the next).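

In this assay the aromatic carbon of the shared core is sensitive to the group it carries: 3,5-dimethylbenzyl in place of phenyl gives a 7.6-fold lower number from compound 2 to compound 4 (0.88 log units; beyond the scatter) and stands as the lowest of the series. Against 3-methoxyphenoxy at the same carbon it gives a 3.5-fold lower number from compound 1 to compound 4 (0.54 log units; beyond the scatter) and so widens the range seen at this position. No evidence at hand accounts for the drop.

The compounds shown do not separate the methylene link from the two methyl groups, and plain benzyl would address that. From the compounds shown here alone, how an amine or a carboxylic acid on that ring would fare also remains open.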